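The source may report more compounds than this note shows. Statements on the series, on what has been measured and on what is new or still open speak of the compounds shown alone.

Going by the values given here, compound 1 `COc1ccc(C(=O)c2cc(OC)c(OC)c(OC)c2)cc1NC(=O)/C=C/c1ccc(F)cc1` gives 300 nM in a functional assay on ME-180 cells (Homo sapiens) for cytotoxicity, read by MTT assay, with a stated time of 72 h (on this read-out higher numbers stand for weaker inhibition and lower numbers for stronger inhibition), the lowest of the three numbers so far. Compound 2 `COc1cc(/C=C/C(=O)Nc2cc(C(=O)c3cc(OC)c(OC)c(OC)c3)ccc2OC)ccc1F` gives 15500 nM, and compound 3 `COc1ccc(C(=O)c2cc(OC)c(OC)c(OC)c2)cc1NC(=O)/C=C/c1cccc(OC(F)(F)F)c1` gives 9200 nM; the step of a 31-fold higher number from compound 1 to compound 3 (1.49 log units; beyond the scatter) is large, while a 1.7-fold lower number from compound 2 to compound 3 (0.23 log units; within the scatter) is not. Compound 4 `COc1cc(C(=O)c2cc(OC)c(OC)c(OC)c2)cc(NC(=O)/C=C/c2ccc(F)cc2)c1OC` differs from compound 1 by methoxy in place of hydrogen on an aromatic carbon. The measured step that bears on this is a 52-fold higher number from compound 1 to compound 2 (1.71 log units; beyond the scatter), the same kind of change but at a different aromatic carbon, and it was large. A weakening of similar order is therefore expected, with a 10-fold higher number from compound 1 to compound 4 (1.00 log units; beyond the scatter). Compound 4 is estimated at 3000 nM in this assay, within 600 nM to 15000 nM.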

Compound 4, half-maximal inhibitory concentration: 1000 nM
For compound 4 the middle estimate is 3.0-fold (0.48 log units) above the measured one; the measured number falls inside the stated range.
By their numbers in this assay, from the lowest: compound 1; then compound 4; then compounds 3 and 2 (each within the scatter of the next).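

In this assay, methoxy in place of hydrogen on the aromatic carbon ortho to a methoxy group gives a 3.3-fold higher number from compound 1 to compound 4 (0.52 log units; beyond the scatter), so this position carries a real but modest cost. The same replacement at a different aromatic carbon costs more, with a 52-fold higher number from compound 1 to compound 2 (1.71 log units; beyond the scatter), which shows that the size of the step depends on where the methoxy sits. No measurement given here bears on the reason for this difference. Still open, from the compounds shown here alone, is how a hydroxyl, an ethoxy or an amine at this carbon would compare with hydrogen and methoxy.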